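The source may report more compounds than this note shows. Statements on the series, on what has been measured and on what is new or still open speak of the compounds shown alone.

Measured compounds:
- compound 1, `COc1cc(-c2cc(/C=C/C(=O)c3ccc(N)cc3)[nH]n2)cc(OC)c1OC`: 99%
- compound 2, `COc1cc(-c2cc(/C=C/C(=O)c3ccc(Cl)c(Cl)c3)[nH]n2)cc(OC)c1OC`: 94%
- compound 3, `COc1ccc(C(=O)/C=C/c2cc(-c3cc(OC)c(OC)c(OC)c3)n[nH]2)cc1`: 99%

All three numbers come from a functional assay on SF-539 cells (Homo sapiens) for cytotoxicity, read by sulforhodamine B assay, with a stated time of 48 h, tested at 0.1 uM; a higher number here means a weaker effect of the compound at the concentration tested, a lower number a stronger effect. Compound 3 stands level with compound 1 at the digits printed, the two together being the highest of the three numbers; the nearest neighbour of compound 3 is compound 1 with no change at the digits printed from compound 1 to compound 3 (within the scatter), the furthest is compound 2 with a number 5 percentage points higher from compound 2 to compound 3 (within the scatter). The whole spread of the series is thus inside the scatter, and none of the three compounds can be called more or less active than another at this concentration.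

Compound 4, `COc1cc(-c2cc(/C=C/C(=O)c3ccc(F)c(F)c3)[nH]n2)cc(OC)c1OC`, is not yet measured in this assay. It differs from compound 3 in one place: 3,4-difluorophenyl in place of 4-methoxyphenyl on a carbonyl carbon. Among the compounds with values here, the steps that bear on this change are the two that swap the aryl group on the carbonyl carbon, a number 5 percentage points lower from compound 1 to compound 2 (within the scatter) and a number 5 percentage points higher from compound 2 to compound 3 (within the scatter); both are within the scatter, so exchanging one aryl group for another has so far moved nothing beyond noise. Compound 4 is therefore expected to remain near the level of compound 3, with a step of a number 3 percentage points lower from compound 3 to compound 4 (within the scatter) that is not expected to exceed the scatter.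

For compound 4 the estimated value in this assay is 96%, with a range from 87% to 102%.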

Compound 4, a percentage reported as activity, at one concentration (the size of the read-out at that concentration, not a potency): 97%
Beside the measured number, compound 4's estimate is 1 percentage points below it, within the range that was stated.
By their numbers in this assay, from the lowest: compounds 2, 4, 1 and 3 (each within the scatter of the next).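

In this assay the 3,4-difluorophenyl on the carbonyl carbon gives a fourth aryl group, and its reading lies within the scatter of all three others, with a number 2 percentage points lower from compound 3 to compound 4 (within the scatter) and a number 3 percentage points higher from compound 2 to compound 4 (within the scatter) and a number 2 percentage points lower from compound 1 to compound 4 (within the scatter) as the steps. The step from the 4-methoxyphenyl takes away the hydrogen-bond acceptor counted on that group, and the step from the 3,4-dichlorophenyl exchanges chlorine for fluorine, yet neither goes beyond the scatter at the concentration tested. No measurement at hand bears on a cause for this flat reading.

All four compounds carry the same core and are read at a single concentration, so these numbers cannot tell whether the aryl groups would separate at other concentrations or whether changes to the core would matter. On these data alone, it also stays open whether a non-aryl group on the carbonyl carbon, such as a saturated alkyl chain or one ending in a carboxylic acid, would move the number beyond the scatter.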